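Swapping methoxy for bromo in compound 3

A few compounds are considered here, and "the series" means these few. Any claim that something is new, unique, unknown or untested is made for them only; others in the source may bear on it.

Among the measured compounds shown here, in a functional assay on A549 cells (Homo sapiens) for antiproliferative activity, read by MTT assay (a higher number here means a weaker inhibitor, a lower number a stronger inhibitor), compound 3 `COc1ccc(-c2ccnc(Nc3cccc(OC)c3)n2)cc1` gives 6530 nM, the lowest number of the three measured so far. Compound 2 `COc1cccc(Nc2nccc(-c3ccc(F)cc3)n2)c1` gives 35900 nM, and compound 1 `Cc1cccc(Nc2nccc(-c3ccc(Br)cc3)n2)c1` gives 63200 nM. Both gaps to compound 3 lie beyond the scatter.

The next compound, compound 4 `COc1cccc(Nc2nccc(-c3ccc(Br)cc3)n2)c1`, has bromo in place of methoxy on an aromatic carbon, para to a large group (bromo in place of methoxy on an aromatic carbon). The closest evidence is a single measured step at this same place, methoxy in place of fluoro, which gave a 5.5-fold lower number from compound 2 to compound 3 (0.74 log units; beyond the scatter). That step was modest but beyond the scatter. Here methoxy leaves instead of entering, so a step of similar size in the opposite direction is expected in this assay, towards a higher number. Bromo is not fluoro, however, so this transfer is uncertain. For the measured compounds named here, compound 1 also carries bromo, but no measured step ties it to compound 4.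

The expected change is a 4.6-fold higher number from compound 3 to compound 4 (0.66 log units; beyond the scatter).

Compound 4 is estimated at 30000 nM, with an expected range of 11000 nM to 70000 nM.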

Compound 4, half-maximal inhibitory concentration: 82700 nM
Compound 4: middle estimate off by 2.8-fold (0.44 log units), on the low side; measured number above the stated range.
By their numbers in this assay, from the lowest: compound 3; then compounds 2, 1 and 4 (each within the scatter of the next, the first and the last beyond it).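

In this assay, with the group on an aromatic carbon para to a large group, bromo in place of methoxy gives a 13-fold higher number from compound 3 to compound 4 (1.10 log units; beyond the scatter) as a large step, so the methoxy result at this place now stands against two halogens rather than one. The two halogens are not interchangeable here, since bromo in place of fluoro gives a 2.3-fold higher number from compound 2 to compound 4 (0.36 log units; beyond the scatter) as a modest step beyond the scatter. A different swap, with bromo kept in place, gives a 1.3-fold higher number from compound 1 to compound 4 (0.12 log units; within the scatter) and so does not separate those two compounds.

Nothing measured here explains why methoxy stands apart at this place.

Going by these compounds, whether an amine or a longer chain such as ethoxy would behave like methoxy at this place remains open.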